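Benzoyl to 2,6-dichlorobenzyl on the ring amine of compound 2

A few compounds are considered here, and "the series" means these few. Any claim that something is new, unique, unknown or untested is made for them only; others in the source may bear on it.

In a functional assay on cells (T-cell, Homo sapiens) for inhibition (on this read-out lower numbers stand for stronger inhibition and higher numbers for weaker inhibition), compound 2 `COc1ccc(-c2cnc3nc(N)nc(N4CCN(C(=O)c5ccccc5)CC4)c3n2)cc1OC` gives 400 nM. That is the lower of the two numbers recorded, but compound 3 `COc1ccc(-c2cnc3nc(N)nc(NC(C)C)c3n2)cc1OC` sits close by with 600 nM, and the gap between compound 2 and compound 3 stays within the scatter of the measurement, so no order between the two can be claimed. Compound 1 `CCOc1nc(N)nc2ncc(-c3ccc(Cl)c(Cl)c3)nc12` gives only a limit and no number, > 10000 nM. The series holds one such entry, (the limit of > 10000 nM in this assay, at which 1 of the 3 values shown sits).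

Compound 4 `COc1ccc(-c2cnc3nc(N)nc(N4CCN(Cc5c(Cl)cccc5Cl)CC4)c3n2)cc1OC` has not yet been measured. It differs from compound 2 in a single place: 2,6-dichlorobenzyl in place of benzoyl on an amine nitrogen in a ring. Within the data shown here, no measured pair covers a change of this kind, so the size of the step from compound 2 to compound 4 is not fixed by anything in hand. The expectation is for a step of modest size at most, in either direction, quite possibly none beyond the scatter, with the wide spread reflecting how little the measured compounds say about this group.

For compound 4 the estimate in this assay is 500 nM, with a range from 100 nM to 3000 nM. This expectation amounts to a 1.3-fold higher number from compound 2 to compound 4 (0.10 log units; within the scatter).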

Compound 4, half-maximal inhibitory concentration: 7600 nM
The estimate for compound 4 lay 15-fold (1.18 log units) below the measured number; measured number outside the range, above it.
By their numbers in this assay, from the lowest: compounds 2 and 3 (each within the scatter of the next); then compound 4. At a limit, above all of these: compound 1.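

Notes on the amine nitrogen in the ring: in this assay the change to 2,6-dichlorobenzyl gives a 19-fold higher number from compound 2 to compound 4 (1.28 log units; beyond the scatter), a step well beyond the scatter. Among these compounds, this is the first measured step at this position, and it shows that the group on this nitrogen has a strong bearing on the read-out: both groups carry a six-membered aromatic ring of carbon only, yet the exchange costs most of the inhibition seen with benzoyl. Nothing in hand bears on the reason for this step.

The change removes the carbonyl and brings in two chlorine atoms at once, so the compounds shown do not tell which of these parts carries the loss. From the compounds shown here alone, an unsubstituted benzyl or a 2,6-dichlorobenzoyl on the same nitrogen would separate the two parts, and it remains open whether a small acyl group such as acetyl, or the free ring amine, would stay close to compound 2 or fall towards compound 4.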